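The source may hold more compounds than are shown below. What is called first, only, known or untested is meant among the compounds shown, and "the series" means these compounds.

Measured so far in a functional assay on M21 cells (Homo sapiens) for antiproliferative activity, read by sulforhodamine B assay, with a stated time of 48 h; on this read-out lower numbers stand for stronger inhibition and higher numbers for weaker inhibition:
- compound 1 `CCc1ccccc1NS(=O)(=O)c1ccc(N2CCNC2=O)cc1`: 180 nM
- compound 2 `O=C1NCCN1c1ccc(S(=O)(=O)Nc2ccc(I)cc2)cc1`: 260 nM
- compound 3 `Cc1cc(C)cc(NS(=O)(=O)c2ccc(N3CCNC3=O)cc2)c1`: 63 nM

Not yet measured: compound 4 `O=C1NCCN1c1ccc(S(=O)(=O)Nc2cccc(Cl)c2)cc1`

The three measured compounds share one core and differ only in the group on a sulfonamide nitrogen. Compound 3 gives the lowest number of the three, and both of its steps below are beyond the scatter: a 2.9-fold lower number from compound 1 to compound 3 (0.46 log units; beyond the scatter), and a 4.1-fold lower number from compound 2 to compound 3 (0.62 log units; beyond the scatter).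

Compound 4 keeps the shared core and changes that one group: 3-chlorophenyl in place of 3,5-dimethylphenyl on a sulfonamide nitrogen. In words, this is 3-chlorophenyl in place of 3,5-dimethylphenyl on a sulfonamide nitrogen.

Among the compounds with values here, no measured step makes this exact swap, so the closest evidence comes from the other changes at the same place. Both of the other groups gave higher numbers than the 3,5-dimethylphenyl group, as the two modest steps above show. The step between those two groups, a 1.4-fold higher number from compound 1 to compound 2 (0.16 log units; within the scatter), stays within the scatter. Three compounds make only a thin basis, but a modest rise in this assay is the reasonable expectation.

The expected change is a 2.4-fold higher number from compound 3 to compound 4 (0.38 log units; beyond the scatter). For compound 4 the estimate is 150 nM, with an expected range of 60 nM to 380 nM.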

Compound 4, half-maximal inhibitory concentration: 25 nM
Compound 4: middle estimate off by 6.0-fold (0.78 log units), on the high side; the measured number lies below the stated range.
By their numbers in this assay, from the lowest: compound 4; then compound 3; then compounds 1 and 2 (each within the scatter of the next).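

In this assay the swap to 3-chlorophenyl gives a 2.5-fold lower number from compound 3 to compound 4 (0.40 log units; beyond the scatter) and so shows that the 3,5-dimethylphenyl group did not mark the floor at this place on the sulfonamide nitrogen, even though the group entering has one heavy atom fewer; compound 4 now has the lowest number of the four, with every step to the others beyond the scatter. Carrying a halogen is not enough by itself: 3-chlorophenyl and 4-iodophenyl each carry one, yet the change between them gives a 10-fold lower number from compound 2 to compound 4 (1.02 log units; beyond the scatter) in the same assay, while the change from the 2-ethylphenyl group gives a 7.2-fold lower number from compound 1 to compound 4 (0.86 log units; beyond the scatter) in that assay as well. Nothing measured here accounts for these differences.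

The compounds shown leave open whether the gain belongs to chlorine itself or to where the group sits, a question that a 4-chlorophenyl, 3-iodophenyl or 3-methylphenyl group could help to settle. They also leave open how far the trend runs with a 3,5-dichlorophenyl group, or whether a ring carrying an amine or a carboxylic acid would keep numbers this low.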